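Carboxypropylsulfanyl analogue of a uracil dinucleotide agonist

A few compounds are considered here, and "the series" means these few. Any claim that something is new, unique, unknown or untested is made for them only; others in the source may bear on it.

Measured so far:
compound 1 `C=CCSc1ccn([C@@H]2O[C@H](COP(=O)(O)OP(=O)(O)O)[C@@H](O)[C@H]2O)c(=O)n1` — 560 nM
compound 2 `O=c1ccn([C@@H]2O[C@@]3(COP(=O)(O)OP(=O)(O)O)C[C@H]3[C@H]2O)c(=O)[nH]1` — 3500 nM

Both compounds were run in an in vitro functional assay on 1321-N1 cells for agonist activity at P2Y purinoceptor 6 (Homo sapiens); on this read-out higher numbers stand for an effect only at larger amounts of compound and lower numbers for an effect already at smaller amounts. Compound 1 gives 560 nM and stands at the lowest of the two numbers; compound 2, with 3500 nM, lies beyond the scatter above it. Going by the values given here, the two differ at several places of the shared core, so no single structural step connects them and nothing more is drawn from that pair.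

Compound 3 `O=C(O)CCCSc1ccn([C@@H]2O[C@H](COP(=O)(O)OP(=O)(O)O)[C@@H](O)[C@H]2O)c(=O)n1` is not yet measured. It departs from compound 1 at one place only: 2-carboxyethyl in place of vinyl on a saturated chain carbon bound to a sulfur. Cut one bond further out, the change reads allylsulfanyl to (3-carboxypropyl)sulfanyl. Among the compounds with values here, no measured pair shows what such a change does in this assay, so the expectation rests on compound 1 alone. Compound 3 is expected to stay in the same region as compound 1, with a step of a 2.7-fold higher number from compound 1 to compound 3 (0.43 log units; beyond the scatter) judged most likely, a modest move to a higher number that could still fall within the scatter. The estimate for compound 3 in this assay is 1500 nM, with a range from 400 nM to 6000 nM.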

Compound 3, half-maximal effective concentration: 8800 nM
The estimate for compound 3 lay 5.9-fold (0.77 log units) below the measured number; measured number outside the range, above it.
By their numbers in this assay, from the lowest: compound 1; then compound 2; then compound 3.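

In this assay, 2-carboxyethyl in place of vinyl on a saturated chain carbon bound to a sulfur gives a 16-fold higher number from compound 1 to compound 3 (1.20 log units; beyond the scatter) and so marks this place as one where the choice of group matters strongly to the read-out. The change from allylsulfanyl to (3-carboxypropyl)sulfanyl does not abolish the read-out, since compound 3 still gives a number (8800 nM), but the effect then appears only at larger amounts of compound. Nothing available on either group accounts for the size of this step.

This single step lengthens the chain and adds the carboxylic acid together, so the compounds shown cannot separate the two contributions; a plain butyl chain, which keeps the length without the acid, and a methyl ester, a primary amide or an amine in place of the carboxylic acid would each help to pull them apart. As far as these compounds go, whether a group smaller than allyl, such as methyl or ethyl, would move the number lower or higher than that of compound 1 also remains open.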